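A Methyl Added to the Weakest Member of the Series

The source may hold more compounds than are shown below. What is called first, only, known or untested is meant among the compounds shown, and "the series" means these compounds.

Compound 1 `Oc1cc(-c2ccc3ccccc3c2)nc2ncccc12` is the weakest of the three measured compounds. In a functional assay on cells (Tumor Cell line, Homo sapiens) for antiproliferative activity (on this read-out lower numbers stand for stronger inhibition of growth and higher numbers for weaker inhibition of growth), compound 1 gives 8130 nM. Compound 2 `Cc1ccnc2nc(-c3cccc4ccccc34)cc(O)c12` is built on a different core and carries a methyl group; in this assay compound 2 gives 35.5 nM. How the core of compound 1 differs from the core of compound 2 is not broken down here, so only their two values show the gap. Compound 3 `Cc1cc(C)c2c(O)cc(-c3cccc4ccccc34)nc2n1` adds a second methyl to compound 2, (methyl in place of hydrogen on an aromatic carbon), and in this assay compound 3 gives 1050 nM. For the measured compounds named here, that step, a 30-fold higher number from compound 2 to compound 3 (1.47 log units; beyond the scatter), is the only measured example of a methyl entering within this set.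

Compound 4 `Cc1ccnc2nc(-c3ccc4ccccc4c3)cc(O)c12` is compound 1 with one added carbon: methyl in place of hydrogen on an aromatic carbon. This is the same kind of change as from compound 2 to compound 3, but not the same: there the methyl entered next to the ring nitrogen, meta to a methyl group and para to a fused ring, whereas in compound 4 it enters ortho to a fused ring and opposite the ring nitrogen. Going by the values given here, the one measured step of this kind, a 30-fold higher number from compound 2 to compound 3 (1.47 log units; beyond the scatter), therefore concerns a different place and is a weak guide; compound 2, which itself carries a methyl and gives 35.5 nM, points toward no penalty. The step from compound 1 to compound 4 is expected to be modest, a 2.7-fold lower number from compound 1 to compound 4 (0.43 log units; beyond the scatter). For compound 4 a value of 3000 nM is estimated, lying between 600 nM and 15000 nM.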

Compound 4, concentration for 50% growth inhibition: 1200 nM
Beside the measured number, compound 4's estimate is 2.5-fold (0.40 log units) above it, within the range that was stated.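

In this assay, methyl in place of hydrogen on an aromatic carbon, ortho to a fused ring and opposite the ring nitrogen, gives a 6.8-fold lower number from compound 1 to compound 4 (0.83 log units; beyond the scatter), so on this core the added methyl goes with stronger inhibition of growth. Set beside the earlier step, the same kind of change does not carry over from one core to the other, in either direction or size: the same change on two cores in this assay, a 30-fold higher number (1.47 log units; beyond the scatter) from compound 2 to compound 3 and a 6.8-fold lower number (0.83 log units; beyond the scatter) from compound 1 to compound 4, 200-fold (2.30 log units) apart, beyond the scatter of two such steps. This does not show that the core alone sets the outcome, since the methyl enters at a different place in each step, and the two steps together cannot separate core from place or give a rule for the whole series.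

The compounds shown leave open whether a methyl at the place it occupies in compound 3 would also bring a higher number when added to compound 4, which would test place and core one at a time. They also leave open how the same ring carbon would respond to something other than a methyl, such as an ethyl chain, an amine or a carboxylic acid.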